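Methoxy in Place of Hydroxy: Expected Effect on Cell Growth

A few compounds are considered here, and "the series" means these few. Any claim that something is new, unique, unknown or untested is made for them only; others in the source may bear on it.

Measured compounds:
compound 1 `O=C(Nc1cccc(-n2cc(-c3ccncc3)c(-c3cc(O)cc(Cl)c3)n2)c1)Nc1ccc(Cl)c(Cl)c1`: 90%
compound 2 `COc1cc(Cl)cc(-c2nn(-c3cccc(NC(=O)Nc4cc(C(F)(F)F)cc(C(F)(F)F)c4)c3)cc2-c2ccncc2)c1`: 28%

In a functional assay on SNB-19 cells (Homo sapiens) for inhibition, read by sulforhodamine B assay, with a stated time of 48 h, tested at 1 uM (on this read-out lower numbers stand for a stronger effect and higher numbers for a weaker effect at the one concentration tested), compound 1 gives the higher of the two numbers, the weaker effect, and compound 2 gives 28%, a gap beyond the scatter. Compound 3 `COc1cc(Cl)cc(-c2nn(-c3cccc(NC(=O)Nc4ccc(Cl)c(Cl)c4)c3)cc2-c2ccncc2)c1` has not been measured yet. It differs from compound 1 by methyl in place of hydrogen on an oxygen on an aromatic ring. Going by the values given here, compound 2 also carries a methoxy group, but its urea end differs too, so no single step is known. A move toward lower numbers is expected, of about a number 30 percentage points lower from compound 1 to compound 3 (beyond the scatter). For compound 3 the estimate is 60%, between 25% and 95%.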

Compound 3, a percentage reported as activity, at one concentration (the size of the read-out at that concentration, not a potency): 89%
The estimate for compound 3 lay 29 percentage points below the measured number; measured number inside the range.
By their numbers in this assay, from the lowest: compound 2; then compounds 3 and 1 (each within the scatter of the next).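

Putting methyl in place of hydrogen on this oxygen gives, in this assay, a number 1 percentage points lower from compound 1 to compound 3 (within the scatter). With the urea end of compound 1 kept, hydroxy and methoxy at this position cannot be told apart at the one concentration tested, so methoxy alone does not account for the low number of compound 2, 28%, whose urea end also differs. Nothing measured here gives a reason for this result.

On these data alone, whether an ethoxy group or an amine on this carbon would read differently remains open. So does whether hydroxy and methoxy also match with the urea end of compound 2.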